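Moving the methoxy group around the anilide ring

The source may hold more compounds than are shown below. What is called first, only, known or untested is meant among the compounds shown, and "the series" means these compounds.

Measured compounds:
`CCOc1ccc(NC(=O)/C=C/c2coc3cc(OC)ccc3c2=O)cc1` compound 1: > 100000 nM
`COc1ccc2c(=O)c(/C=C/C(=O)Nc3ccccc3OC)coc2c1` compound 2: 17600 nM
`COc1ccc(NC(=O)/C=C/c2coc3cc(OC)ccc3c2=O)cc1` compound 3: > 100000 nM

In a functional assay (QGY7701 cells, Homo sapiens) for inhibition, read by MTT assay, with a stated time of 48 h (a higher number here means a weaker inhibitor, a lower number a stronger inhibitor), compound 2 gives 17600 nM. Compound 1 gives only a limit of this assay, > 100000 nM. Compound 3 likewise gives only a limit, > 100000 nM. Compound 3 thus stands at the limit, where two of the three values sit (the limit of > 100000 nM in this assay, at which 2 of the 3 values shown sit), and no number separates it from compound 1; the step between them is unreadable a step that the two limits leave unreadable from compound 1 to compound 3.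

The unmeasured compound 4 `COc1cccc(NC(=O)/C=C/c2coc3cc(OC)ccc3c2=O)c1` differs from compound 3 in one place: 3-methoxyphenyl in place of 4-methoxyphenyl on an amide-type nitrogen.

Going by the values given here, two measured steps bear on this change. Moving from compound 1 to compound 2 gave an at least 5.6-fold lower number from compound 1 to compound 2 (0.75 log units; beyond the scatter), and moving from compound 2 to compound 3 gave an at least 5.6-fold higher number from compound 2 to compound 3 (0.75 log units; beyond the scatter). Among the compounds with values here, both concern the position of the alkoxy group on the anilide ring, and the 2-methoxyphenyl compound is the only one with a readable number. Within the data shown here, no measured step covers 3-methoxyphenyl itself.

The expectation for compound 4 is therefore uncertain: a number somewhat lower than the limit seen for compound 3 is possible, though a further limit is about as likely. Compound 4 is expected at 50000 nM, within 10000 nM to 200000 nM, which means an expected step of an at least 2.0-fold lower number from compound 3 to compound 4 (0.30 log units; that floor lies within the scatter).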

Compound 4, half-maximal inhibitory concentration: 39100 nM
Beside the measured number, compound 4's estimate is 1.3-fold (0.11 log units) above it; low and high end bracket the measured number.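

In this assay, the 3-methoxyphenyl group on the amide-type nitrogen gives a second readable number, with an at least 2.5-fold lower number from compound 3 to compound 4 (0.40 log units; beyond the scatter), so a readable number is no longer confined to the 2-methoxyphenyl compound. Against that compound the change runs the other way, with a 2.2-fold higher number from compound 2 to compound 4 (0.35 log units; beyond the scatter), which places compound 2 as the strongest of the set, compound 4 behind it, and compound 3 last. The 4-ethoxyphenyl group falls behind the 3-methoxyphenyl group as well, with an at least 2.5-fold lower number from compound 1 to compound 4 (0.40 log units; beyond the scatter), so among the compounds shown both groups carrying their alkoxy chain at the 4-position read weaker than those carrying it at the 2- or 3-position.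

From the compounds shown here alone, the steps from compound 1 and compound 3 are floors only, so how far these two lie from compound 4 stays unknown, and nothing separates them from each other: the limit of > 100000 nM in this assay, at which 2 of the 4 values shown sit. The compounds shown also leave open how an amine or a carboxylic acid in place of the methoxy group would read on this phenyl ring, and whether a longer chain such as butoxy would hold the number of compound 2 or compound 4.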